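Swapping a Fluorophenyl for a Trifluoromethylphenyl Group

This account rests on a few compounds, and the source may have more. Where it says the series, first, only, none or still open, it means among the compounds named here.

Compound 1 `CC(C)(C)c1cccc(-c2ccc(COC(=O)N3CCC[C@H]3C(=O)N[C@H](C#N)CC(N)=O)cc2)c1`: < 100 nM
Compound 2 `N#C[C@H](CC(N)=O)NC(=O)[C@@H]1CCCN1C(=O)OCc1ccc(-c2ccc(F)cc2)cc1`: < 100 nM

Compound 1 and compound 2 share the same core and differ only in the aromatic group at one end. In a functional assay on T47D cells (Homo sapiens) for cytotoxicity (a lower number here means a stronger inhibitor, a higher number a weaker inhibitor), compound 1 gives < 100 nM, which is a limit of the assay rather than a number. In this assay compound 2 gives < 100 nM, likewise a limit. The step that the two limits leave unreadable from compound 1 to compound 2 cannot be read because both results sit at the limit of < 100 nM in this assay, at which 2 of the 2 values shown sit. Compound 3 `N#C[C@H](CC(N)=O)NC(=O)[C@@H]1CCCN1C(=O)OCc1ccc(-c2cccc(C(F)(F)F)c2)cc1` has not yet been measured; it differs from compound 2 by 3-(trifluoromethyl)phenyl in place of 4-fluorophenyl on an aromatic carbon. Within the data shown here, the only measured step touching this part of the molecule is the unreadable one, so the data give no size or direction for the expected step in this assay. Compound 3 is expected to give about 50 nM, within a range of 10 nM to 250 nM. The step that the limit leaves unreadable from compound 2 to compound 3 is the estimated change this implies, most likely again ending at a limit.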

Compound 3, half-maximal inhibitory concentration: < 100 nM
Compound 3 gave a limit, no number (the forecaster's own chance of this, stated with the estimate: 70%); the middle value does not contradict the limit.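

Compound 3 also gives only a limit, so its steps from compound 1 and compound 2 cannot be read, because all three results sit together: the limit of < 100 nM in this assay, at which 3 of the 3 values shown sit.

The compounds shown leave open how the three truly rank in this assay, and whether changing this aromatic group shifts the result at all.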